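Sulfonyl for carbonyl on the shared amine

The source may report more compounds than this note shows. Statements on the series, on what has been measured and on what is new or still open speak of the compounds shown alone.

Of the compounds shown here, three have been measured in a functional assay on HL-60 cells (Homo sapiens) for antiproliferative activity, read by MTT assay, with a stated time of 72 h; a higher number here means a weaker inhibitor, a lower number a stronger inhibitor. Compound 1 `CC(=O)N(C)c1ccc2[nH]c(-c3n[nH]c4ccccc34)cc2n1` gives 5110 nM; compound 2 `COc1ccc(C(=O)N(C)c2ccc3[nH]c(-c4n[nH]c5ccccc45)cc3n2)cc1` gives 3320 nM; compound 3 `COc1cccc(C(=O)N(C)c2ccc3[nH]c(-c4n[nH]c5ccccc45)cc3n2)c1` gives 1420 nM. Compound 3 stands lowest of the three, with a 2.3-fold lower number from compound 2 to compound 3 (0.37 log units; beyond the scatter) and a 3.6-fold lower number from compound 1 to compound 3 (0.56 log units; beyond the scatter), while a 1.5-fold lower number from compound 1 to compound 2 (0.19 log units; within the scatter) lies within the scatter.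

Compound 4 `CN(c1ccc2[nH]c(-c3n[nH]c4ccccc34)cc2n1)S(=O)(=O)c1ccc(Cl)cc1` is not yet measured. Its difference from compound 3 is (4-chlorophenyl)sulfonyl in place of (3-methoxyphenyl)carbonyl on a nitrogen on an aromatic ring. Two things change at once: the carbonyl gives way to a sulfonyl, and the ring substituent moves from methoxy to chloro with a different attachment point on the ring. For the measured compounds named here, none of the measured steps covers a sulfonyl, so no step bears directly on the change. Going by the values given here, the measured steps show only that an aryl group on the carbonyl lowers the number modestly against methyl, and that the two methoxy positions differ by a modest step. The new linker removes any basis for transferring those steps. The expectation for compound 4 is therefore a number in the range the measured aryl compounds occupy, with a wide margin: compound 4 is estimated at 2500 nM, between 600 nM and 10000 nM, which would mean a step of a 1.8-fold higher number from compound 3 to compound 4 (0.25 log units; within the scatter), not judged beyond the scatter.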

Compound 4, half-maximal inhibitory concentration: 770 nM
Compound 4: middle estimate off by 3.2-fold (0.51 log units), on the high side; the range from low to high includes it.
By their numbers in this assay, from the lowest: compounds 4 and 3 (each within the scatter of the next); then compounds 2 and 1 (each within the scatter of the next).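

The nitrogen on the aromatic ring carries a (4-chlorophenyl)sulfonyl group as readily as a (3-methoxyphenyl)carbonyl group in this assay, with a 1.8-fold lower number from compound 3 to compound 4 (0.27 log units; within the scatter) leaving compound 3 and compound 4 without an order. The carbonyl is therefore not required at this position for the lowest numbers in the set. The sulfonyl compound also separates clearly from the other two, with a 4.3-fold lower number from compound 2 to compound 4 (0.63 log units; beyond the scatter) and with a 6.6-fold lower number from compound 1 to compound 4 (0.82 log units; beyond the scatter), and these gaps show that the low end of the series extends beyond the aryl carbonyl pair to a different linker; nothing available explains any of these steps.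

Going by these compounds, because the linker and the ring substituent change together, the part played by each remains open, and a (3-methoxyphenyl)sulfonyl or (4-chlorophenyl)carbonyl group on the same nitrogen would separate them. Also open, on these data alone, is how this assay would read an amine or a carboxylic acid on that phenyl ring, or a longer chain in place of the methyl on the nitrogen.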